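Ileum H1 antagonism series: guanidine-linked diaryl chains

A few compounds are considered here, and "the series" means these few. Any claim that something is new, unique, unknown or untested is made for them only; others in the source may bear on it.

Measured so far:
compound 1 `N=C(NCCCc1c[nH]cn1)NCCCC(c1ccccc1)c1ccccn1` — 251 nM
compound 2 `N=C(NCCCc1c[nH]cn1)NCCC(c1ccc(Cl)cc1)c1ccccn1` — 77.6 nM
compound 3 `N=C(NCCCc1c[nH]cn1)NCCC(c1ccc(F)cc1)c1cccnc1` — 195 nM

All three share the guanidine and imidazole portion and differ in the diaryl end of the chain. In a functional assay on ileum for antagonist activity at histamine H1 receptor (Cavia porcellus) (on this read-out higher numbers stand for weaker binding and lower numbers for tighter binding), compound 3 gives 195 nM, which places it second highest of the three numbers. Compound 1 gives 251 nM, a number within the scatter of that of compound 3, so the two cannot be ordered. Compound 2 gives 77.6 nM, a lower number than compound 3 by a margin beyond the scatter. No pair of these compounds differs in a single place, so no step can be isolated from them.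

Compound 4 `N=C(NCCCc1c[nH]cn1)NCCC(c1ccccc1)c1ccc(F)cc1` has not been measured. It is derived from compound 3 by phenyl in place of pyridin-3-yl on a saturated chain carbon bound to an aromatic carbon and a saturated chain carbon. The measured compounds offer no single-change comparison that bears on this swap, so the size and direction of the step in this assay are open. The expectation is that compound 4 falls close to compound 3, with a step of a 1.2-fold lower number from compound 3 to compound 4 (0.09 log units; within the scatter) not beyond the scatter. On that basis compound 4 is estimated at 160 nM, within a range from 50 nM to 500 nM.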

Compound 4, dissociation constant: 34.7 nM
For compound 4 the middle estimate is 4.6-fold (0.66 log units) above the measured one, and the stated range ends above it.
By their numbers in this assay, from the lowest: compound 4; then compound 2; then compounds 3 and 1 (each within the scatter of the next).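

In this assay, within the data shown here, phenyl in place of pyridin-3-yl on a saturated chain carbon bound to an aromatic carbon and a saturated chain carbon gives a 5.6-fold lower number from compound 3 to compound 4 (0.75 log units; beyond the scatter) as the first single-place comparison. Among these compounds, this position therefore responds to the identity of the ring, which the earlier compounds could not show because no pair of them differed in one place. The change removes the ring nitrogen and the one hydrogen-bond acceptor counted on the leaving group, but no available measurement accounts for the size of the step.

As far as these compounds go, whether the same swap gives a similar step on the chlorine-bearing compound 2 or on the longer chain of compound 1 remains open. So does the effect of a different group at this position, such as a thiophene ring or a cyclohexyl ring.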